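The source may report more compounds than this note shows. Statements on the series, on what has been measured and on what is new or still open speak of the compounds shown alone.

In an ADME assay on microsomes from liver (Rattus norvegicus) for metabolic stability (a higher number here means that the compound lasts longer, a lower number that the compound disappears faster), compound 2 (`COc1cc(OCc2cccc(-c3cnc(OC)nc3)c2)c2cc(-c3cn4nc(OC)sc4n3)oc2c1`) gives 1.03 h, within the scatter of both compound 1 (`COc1cc(OCc2cccc(-c3ccc(C#N)cn3)c2)c2cc(-c3cn4nc(OC)sc4n3)oc2c1`) at 0.833 h and compound 3 (`COc1cc(OCc2csc(-c3ccc(C(C)(C)O)cc3)n2)c2cc(-c3cn4nc(OC)sc4n3)oc2c1`) at 1.15 h. Compound 4 (`COc1cc(OCc2cccc(OCc3ccccc3)c2)c2cc(-c3cn4nc(OC)sc4n3)oc2c1`) has benzyloxy in place of 2-methoxypyrimidin-5-yl on an aromatic carbon, meta to a large group (benzyloxy in place of 2-methoxypyrimidin-5-yl on an aromatic carbon). Among the measured compounds shown here, one measured step bears on this change: a 1.2-fold higher number from compound 1 to compound 2 (0.09 log units; within the scatter), also an exchange of groups on an aromatic carbon. For the measured compounds named here, it stays within the scatter, but no measured compound carries benzyloxy, so the support is thin. No shift beyond the scatter is expected in this assay. The estimated step is a 1.1-fold lower number from compound 2 to compound 4 (0.06 log units; within the scatter). For compound 4 the expected value is 0.9 h, with an estimated range of 0.45 h to 1.7 h.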

Compound 4, half-life: 0.333 h
Estimate against measurement, compound 4: 2.7-fold (0.43 log units) above, and the stated range ends above it.
By their numbers in this assay, from the lowest: compound 4; then compounds 1, 2 and 3 (each within the scatter of the next).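

In this assay, this aromatic carbon, meta to a large group, no longer looks indifferent to what it carries. Benzyloxy brings a 3.1-fold lower number from compound 2 to compound 4 (0.49 log units; beyond the scatter) and a 2.5-fold lower number from compound 1 to compound 4 (0.40 log units; beyond the scatter), whereas exchanging 5-cyanopyridin-2-yl for 2-methoxypyrimidin-5-yl had stayed within the scatter. No measurement at hand accounts for this drop.

The compounds shown leave open whether the drop follows the oxygen-and-methylene link of benzyloxy or its ring of carbon only. A directly attached phenyl and a pyridylmethoxy group would separate the two.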